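Fluorine-bearing aryl variants of a tricyclic antiproliferative core

The source may report more compounds than this note shows. Statements on the series, on what has been measured and on what is new or still open speak of the compounds shown alone.

Compound 1 `CCC1=C(O)c2c(oc(-c3ccc(CC)cc3)cc2=O)C(CC)(CC)C1=O` sets the benchmark in a functional assay on KBVIN cells (Homo sapiens) for antiproliferative activity, read by sulforhodamine B assay, with a stated time of 3 days (a higher number here means that more compound is needed for the effect, a lower number that less compound is needed), giving 0.07 uM. Compound 2 `CCC1=C(O)c2c(oc(-c3ccccc3F)cc2=O)C(CC)(CC)C1=O` gives 3.93 uM in this assay, and compound 3 `CCC1=C(O)c2c(oc(-c3ccc(C)c(F)c3)cc2=O)C(CC)(CC)C1=O` gives 2.95 uM. On these three numbers compound 3 stands second highest, close to compound 2 and far from compound 1. Compound 4 `CCC1=C(O)c2c(oc(-c3cc(C)ccc3F)cc2=O)C(CC)(CC)C1=O` has not yet been measured; it differs from compound 3 in one place: 2-fluoro-5-methylphenyl in place of 3-fluoro-4-methylphenyl on an aromatic carbon.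

For the measured compounds named here, two measured steps bear on this change. Replacing 4-ethylphenyl with a fluorine-bearing ring was costly in both cases, a 56-fold higher number from compound 1 to compound 2 (1.75 log units; beyond the scatter) and a 42-fold higher number from compound 1 to compound 3 (1.62 log units; beyond the scatter), while the two fluorine-bearing rings themselves sit together, a 1.3-fold lower number from compound 2 to compound 3 (0.12 log units; within the scatter). Compound 4 shares the fluorine and methyl of compound 3, only rearranged, and shares the fluorine pattern of compound 2. The account therefore expects no step beyond the scatter, a 1.2-fold higher number from compound 3 to compound 4 (0.07 log units; within the scatter), because the two measured fluorine-bearing analogues differ only by a 1.3-fold lower number from compound 2 to compound 3 (0.12 log units; within the scatter). Compound 4 is estimated at 3.5 uM, with a range from 1.2 uM to 10 uM.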

Compound 4, concentration for half-maximal effect: 3.24 uM
For compound 4 the middle estimate is 1.1-fold (0.03 log units) above the measured one, within the range that was stated.
By their numbers in this assay, from the lowest: compound 1; then compounds 3, 4 and 2 (each within the scatter of the next).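

In this assay the rearrangement of the same atoms, 2-fluoro-5-methylphenyl in place of 3-fluoro-4-methylphenyl, gives a 1.1-fold higher number from compound 3 to compound 4 (0.04 log units; within the scatter) and so the two arrangements cannot be told apart. Methyl in place of hydrogen on the 2-fluorophenyl ring likewise gives a 1.2-fold lower number from compound 2 to compound 4 (0.08 log units; within the scatter) and makes no difference that can be read, while the step from the 4-ethylphenyl ring stays large on this third fluorine-bearing ring too, with a 46-fold higher number from compound 1 to compound 4 (1.67 log units; beyond the scatter) on record. No measurement at hand explains why these three fluorine-bearing rings sit together or why they lie so far from the 4-ethylphenyl ring.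

The compounds shown leave open whether the low number of compound 1 goes with the ethyl group itself or with a ring free of fluorine. Also open, from the compounds shown here alone, is how a propyl chain, a methoxy group or an amine on this aryl ring would read in this assay beside the ethyl group of compound 1.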